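This account rests on a few compounds, and the source may have more. Where it says the series, first, only, none or still open, it means among the compounds named here.

In a functional assay on MCF7 cells (Homo sapiens) for antiproliferative activity, read by sulforhodamine B assay, with a stated time of 48 h (on this read-out lower numbers stand for stronger inhibition and higher numbers for weaker inhibition), compound 2 `O=C1NCCN1c1ccc(S(=O)(=O)Nc2ccc(Br)cc2)cc1` gives 240 nM, the second highest of the three numbers seen so far. Compound 3 `O=C1NCCN1c1ccc(S(=O)(=O)Nc2ccc3[nH]ccc3c2)cc1` gives 170 nM, which lies within the scatter of compound 2, while compound 1 `O=C1NCCN1c1ccc(S(=O)(=O)Nc2ccc(F)c(F)c2)cc1` gives 620 nM. Compound 4 `O=C1NCCN1c1ccc(S(=O)(=O)Nc2ccc(F)cc2)cc1` differs from compound 2 by fluoro in place of bromo on an aromatic carbon. Within the data shown here, the one measured step that bears on this is a 2.6-fold lower number from compound 1 to compound 2 (0.41 log units; beyond the scatter), where the fluorine-carrying ring gave the higher number. Compound 4 goes the other way, putting fluoro in place of bromo, so a modest rise in the number is expected; the step expected from this change is a 1.9-fold higher number from compound 2 to compound 4 (0.27 log units; within the scatter). Compound 4 is therefore estimated to give 450 nM in this assay, with a likely range from 200 nM to 1000 nM.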

Compound 4, half-maximal inhibitory concentration: 690 nM
Estimate against measurement, compound 4: 1.5-fold (0.19 log units) below; low and high end bracket the measured number.
By their numbers in this assay, from the lowest: compounds 3 and 2 (each within the scatter of the next); then compounds 1 and 4 (each within the scatter of the next).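

In this assay, going from 4-bromophenyl to 4-fluorophenyl brings a 2.9-fold higher number from compound 2 to compound 4 (0.46 log units; beyond the scatter), so which halogen sits on this ring carbon matters, not merely that one is there. Hydrogen in place of one fluoro brings a 1.1-fold higher number from compound 1 to compound 4 (0.05 log units; within the scatter), so that fluoro makes no visible difference here. Nothing measured on these compounds explains why the bromo compound gives the lower number. The compounds shown leave open whether chloro, methyl or an amine at this place would give a number nearer the bromo or the fluoro compound.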